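Compound 4: Difluoroethyl in Place of Isopropylsulfanyl

A few compounds are considered here, and "the series" means these few. Any claim that something is new, unique, unknown or untested is made for them only; others in the source may bear on it.

Three compounds share one core and differ only in the group on the carbonyl carbon bonded to the amide-type nitrogen in a ring. In a functional assay on isolated protein for inhibition of Glucose-dependent insulinotropic receptor (Rattus norvegicus), read by HTRF and cAMP accumulation (on this read-out lower numbers stand for an effect already at smaller amounts and higher numbers for an effect only at larger amounts of compound), compound 1 `Cc1nc(S(C)(=O)=O)ccc1Oc1ncnc(OC2CCN(C(=O)O[C@@H](C)CF)CC2)c1F` gives 1680 nM, compound 2 `Cc1nc(S(C)(=O)=O)ccc1Oc1ncnc(OC2CCN(C(=O)OC3(C(F)(F)F)CCC3)CC2)c1F` gives 63.3 nM, and compound 3 `Cc1nc(S(C)(=O)=O)ccc1Oc1ncnc(OC2CCN(C(=O)SC(C)C)CC2)c1F` gives 41.3 nM, the lowest of the three, with compound 2 within the scatter of it and compound 1 far above. Compound 4 `Cc1nc(S(C)(=O)=O)ccc1Oc1ncnc(OC2CCN(C(=O)C(C)(F)F)CC2)c1F` carries 1,1-difluoroethyl in place of isopropylsulfanyl on a carbonyl carbon. Among the measured compounds shown here, two measured steps touch this position: a 41-fold lower number from compound 1 to compound 3 (1.61 log units; beyond the scatter) and a 1.5-fold lower number from compound 2 to compound 3 (0.19 log units; within the scatter). Both compound 1 and compound 2 hold fluorine here yet differ widely (a 27-fold lower number from compound 1 to compound 2 (1.42 log units; beyond the scatter)), so the direction is uncertain, and a modest rise is expected. Compound 4 is estimated at 250 nM (range 50 nM to 1500 nM), an expected step of a 6.1-fold higher number from compound 3 to compound 4 (0.78 log units; beyond the scatter).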

Compound 4, half-maximal effective concentration: 239 nM
Beside the measured number, compound 4's estimate is 1.0-fold (0.02 log units) above it; low and high end bracket the measured number.
By their numbers in this assay, from the lowest: compounds 3 and 2 (each within the scatter of the next); then compound 4; then compound 1.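

In this assay, a carbonyl substituent attached through carbon, 1,1-difluoroethyl, can now be compared with those attached through oxygen or sulfur: it gives a 5.8-fold higher number from compound 3 to compound 4 (0.76 log units; beyond the scatter) and a 3.8-fold higher number from compound 2 to compound 4 (0.58 log units; beyond the scatter), yet still a 7.0-fold lower number from compound 1 to compound 4 (0.85 log units; beyond the scatter). Isopropylsulfanyl and 1,1-difluoroethyl have the same heavy-atom count, so that count alone does not set the number at this position. No measurement here explains the change. The compounds shown leave open how a plain ethyl group or an isopropylamino group would compare on this carbonyl carbon. The part played by the two fluorines of compound 4 therefore stays unresolved.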